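The source may report more compounds than this note shows. Statements on the series, on what has been measured and on what is new or still open speak of the compounds shown alone.

Of the compounds shown here, three have so far been tested in a toxicity assay on NIH3T3 cells (Mus musculus) for cytotoxicity, read by resazurin assay; a higher number here means that more compound is needed for the effect, a lower number that less compound is needed. Compound 1 `CNC(=O)c1ccc(NCc2cncn2Cc2ccc(-c3ccccc3)cc2N)cc1-c1ccccc1` is reported only as a limit, > 1000 nM. Compound 3 `c1ccc(-c2ccc(Cn3cncc3CNc3ccc(-c4ccccc4)c(-c4ccccc4)c3)cc2)cc1` is also reported only as a limit, > 10000 nM. Compound 2 `COC(=O)c1ccc(NCc2cncn2Cc2ccccc2C)cc1-c1ccccc1` gives 10000 nM, which makes it the only one of the three with an actual number.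

Compound 4 `COC(=O)c1ccc(NCc2cncn2Cc2cccc(F)c2)cc1-c1ccccc1` keeps the rest of compound 2 and differs from it in one group: 3-fluorophenyl in place of 2-methylphenyl on a saturated chain carbon bound to an aromatic nitrogen. In words, 3-fluorophenyl stands in place of 2-methylphenyl on a saturated chain carbon bound to an aromatic nitrogen. Cut one bond further out, the same difference reads 2-methylbenzyl to 3-fluorobenzyl. Both groups are counted as the same size, and neither brings any hydrogen-bond donors, acceptors or net charge.

Among the compounds with values here, no two measured compounds differ in only one place, and the effect of such a swap in this assay has not been observed. The expectation therefore rests on compound 2 at 10000 nM, with no step beyond the scatter foreseen in either direction. The estimated step of no change at the digits printed from compound 2 to compound 4 (within the scatter) reflects that expectation. For compound 4 the expected value is 10000 nM, with an estimated range of 4000 nM to 25000 nM.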

Compound 4, half-maximal effective concentration: > 1000 nM
Compound 4: a limit, no number; the forecaster's own chance of this, stated with the estimate: 45%; the middle value does not contradict the limit.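

In this assay compound 4 is reported as > 1000 nM, which is a limit and not a number. Within the data shown here, no step from compound 2 to compound 4 can therefore be read. The compounds shown leave open whether 3-fluorophenyl in place of 2-methylphenyl changes the value in this assay at all, and if so, in which direction.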